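This account rests on a few compounds, and the source may have more. Where it says the series, first, only, none or still open, it means among the compounds named here.

Measured so far:
Compound 1 `C=C(C)[C@@H]1CC=C(Cn2cc(COc3ccc(C4NC(=O)NC(C)=C4C(=O)OCC)cc3)nn2)CC1`: > 100000 nM (a limit)
Compound 2 `C=C(C)[C@@H]1CC=C(Cn2cc(COc3cccc(C4NC(=O)NC5=C4C(=O)CC(C)(C)C5)c3)nn2)CC1`: 51600 nM

In a functional assay on NCI-H460 cells (Homo sapiens) for inhibition, read by sulforhodamine B assay, with a stated time of 48 h (a higher number here means a weaker inhibitor of growth, a lower number a stronger inhibitor of growth), compound 2 gives 51600 nM, the only actual number shown. For compound 1 the value is a limit rather than a number, > 100000 nM. Compound 1 therefore stands at the limit of > 100000 nM in this assay, at which 1 of the 2 values shown sits. Going by the values given here, no single-change step between measured compounds exists here, so nothing shows how a small change shifts this assay. Compound 3 `C=C(C)[C@@H]1CC=C(Cn2cc(COc3cc(C4NC(=O)NC5=C4C(=O)CC(C)(C)C5)ccc3OC)nn2)CC1` differs from compound 2 by methoxy in place of hydrogen on an aromatic carbon. For compound 3 the expected outcome is 60000 nM, between 20000 nM and 100000 nM, a step of a 1.2-fold higher number from compound 2 to compound 3 (0.07 log units; within the scatter) that is expected to stay within the usual scatter.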

Compound 3, concentration for total growth inhibition: > 100000 nM
Compound 3 gave a limit, no number; the forecaster's own chance of this, stated with the estimate: 35%; middle value at least 1.6-fold (0.22 log units) away from the limit.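

In this assay, going by these compounds alone, methoxy in place of hydrogen on an aromatic carbon, ortho to a large group and para to a large group, gives the first single-change step here: an at least 1.9-fold higher number from compound 2 to compound 3 (0.28 log units; that floor lies within the scatter). On these data alone, the value of compound 3, > 100000 nM, is a limit and not a number, so the full size of the step remains unknown. Methoxy at this position brings no visible gain in growth inhibition.

As far as these compounds go, whether a hydroxyl group or an amine at this position would give a lower number remains open. Readings at this end of the scale offer little room for comparison: the limit of > 100000 nM in this assay, at which 2 of the 3 values shown sit.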